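The compounds below may be only part of what the source reports. "The series", "measured", "known", "first", "only" and "open" are said of these compounds alone.

Measured compounds in an assay on CHO cells for displacement of a labelled ligand from adenosine receptor A2b (Homo sapiens), read by scintillation counting, with a stated time of 75 min, in the presence of a further agent that is not named here; a lower number here means a stronger inhibitor, a higher number a weaker inhibitor:
compound 1 `CCCn1c(=O)[nH]c2nc(-c3ccc(S(=O)(=O)N4CCN(c5ccccc5C)CC4)cc3)[nH]c2c1=O` gives 0.432 nM;
compound 2 `CCCn1c(=O)[nH]c2nc(-c3ccc(S(=O)(=O)N4CCN(C)CC4)cc3)[nH]c2c1=O` gives 48.2 nM;
compound 3 `CCCn1c(=O)[nH]c2nc(-c3ccc(S(=O)(=O)N4CCN(c5ccccc5F)CC4)cc3)[nH]c2c1=O` gives 3.22 nM.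

Compound 3 stands second of the three numbers, with a 7.5-fold higher number from compound 1 to compound 3 (0.87 log units; beyond the scatter) and a 15-fold lower number from compound 2 to compound 3 (1.18 log units; beyond the scatter). Compound 4 `CCCn1c(=O)[nH]c2nc(-c3ccc(S(=O)(=O)N4CCN(Cc5ccc(Br)cc5)CC4)cc3)[nH]c2c1=O` differs from compound 3 by 4-bromobenzyl in place of 2-fluorophenyl on an amine nitrogen in a ring. The step that bears most is a 15-fold lower number from compound 2 to compound 3 (1.18 log units; beyond the scatter), which shows that an aromatic ring on this ring nitrogen in place of methyl gives a large gain; a 7.5-fold higher number from compound 1 to compound 3 (0.87 log units; beyond the scatter) shows that changing the substituent on that ring moves the number only modestly. Within the data shown here, no measured step covers a benzyl rather than a phenyl on this nitrogen, so the expected change from compound 3 to compound 4 is small, a 1.9-fold higher number from compound 3 to compound 4 (0.27 log units; within the scatter). Compound 4 is therefore estimated at 6 nM, within 1.5 nM to 25 nM.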

Compound 4, inhibition constant: 0.153 nM
The estimate for compound 4 lay 39-fold (1.59 log units) above the measured number; measured number outside the range, below it.
By their numbers in this assay, from the lowest: compound 4; then compound 1; then compound 3; then compound 2.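

On the amine nitrogen in the ring, 4-bromobenzyl does far better than 2-fluorophenyl (a 21-fold lower number from compound 3 to compound 4 (1.32 log units; beyond the scatter)), so swapping a phenyl-type group for a benzyl-type group here is no minor change. It also beats 2-methylphenyl (a 2.8-fold lower number from compound 1 to compound 4 (0.45 log units; beyond the scatter)) and far exceeds the small methyl group (a 320-fold lower number from compound 2 to compound 4 (2.50 log units; beyond the scatter)), which gives compound 4 the lowest number of the four. No measurement at hand accounts for this gain. On these data alone, whether it depends on the bromine or on the benzyl link stays open, as does how an unsubstituted benzyl, a 4-chlorobenzyl or a longer phenylethyl chain on this nitrogen would compare.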